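Swapping a dimethylaminobenzyl arm for a fluorophenylethyl arm

A few compounds are considered here, and "the series" means these few. Any claim that something is new, unique, unknown or untested is made for them only; others in the source may bear on it.

Compound 3 `Cc1ccc2[nH]c(=O)c(CN(Cc3ccc(N(C)C)cc3)Cc3ccc(C(C)(C)C)cc3)cc2c1` has been tested in a toxicity assay on MDCK cells (Canis lupus familiaris) for cytotoxicity, read by crystal violet staining, with a stated time of 48 h (on this read-out higher numbers stand for lower toxicity in this test and lower numbers for higher toxicity in this test), where compound 3 gives > 5000 nM, which is a limit of the assay rather than a number. Compound 1 `Cc1ccc2[nH]c(=O)c(CN(Cc3ccc(F)cc3)Cc3ccc(C(C)(C)C)cc3)cc2c1` gives > 27000 nM in this assay, again only a limit. Compound 2 `CCOc1ccc(CN(Cc2ccc(C(C)(C)C)cc2)Cc2cc3cc(C)ccc3[nH]c2=O)cc1` gives > 10000 nM, also a limit. With every value a limit, the step that the two limits leave unreadable from compound 1 to compound 3 cannot be sized, nor can the step that the two limits leave unreadable from compound 2 to compound 3. Compound 4 `Cc1ccc2[nH]c(=O)c(CN(Cc3ccc(C(C)(C)C)cc3)C(C)c3ccc(F)cc3)cc2c1` differs from compound 3 by 1-(4-fluorophenyl)ethyl in place of 4-(dimethylamino)benzyl on an amine nitrogen. Compound 4 carries a fluoro-bearing arm much like compound 1. No readable step is available to guide the expectation. Compound 4 is estimated at 30000 nM, with a range from 8000 nM to 100000 nM, most likely reported again only as a limit. For compound 4 the expected step is a step that the limit leaves unreadable from compound 3 to compound 4.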

Compound 4, half-maximal cytotoxic concentration: > 33000 nM
Compound 4 gave a limit, no number (the forecaster's own chance of this, stated with the estimate: 80%); at least 1.1-fold (0.04 log units) between middle value and limit.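

Among the compounds shown here, compound 4 gives only a limit, as do compound 1, compound 2 and compound 3, so no step to compound 4 can be read. As far as these compounds go, whether these amine nitrogen arms differ at all in this assay stays open.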